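The compounds below may be only part of what the source reports. "The series", "measured", "known", "first", "only" and "open" are said of these compounds alone.

Compound 1 `CO[C@H]1CC[C@H](NC(=O)c2n[nH]cc2NC(=O)c2c(C)nc3ccccn23)CC1`: 34000 nM
Compound 2 `COc1cccc(OC)c1C(=O)Nc1c[nH]nc1C(=O)NCc1ccccn1`: > 50000 nM
Compound 3 `COc1cc(OC)c(C(=O)Nc2c[nH]nc2C(=O)N[C@H]2CC[C@H](OC)CC2)c(OC)c1`: > 50000 nM

All three compounds were tested in an ADME assay on MRC5 cells (Homo sapiens) for inhibition, with a stated time of 72 h; on this read-out higher numbers stand for an effect only at larger amounts of compound and lower numbers for an effect already at smaller amounts. Compound 1 gives a number, 34000 nM. For compound 2 the entry > 50000 nM is a limit of the assay and not a number. For compound 3 the entry > 50000 nM is likewise a limit. Compound 2 therefore stands at the limit of > 50000 nM in this assay, at which 2 of the 3 values shown sit, together with compound 3, while compound 1 alone has a measured number.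

Compound 4 `COc1cccc(OC)c1C(=O)Nc1c[nH]nc1C(=O)NC1CCC(C)CC1` has not yet been measured in this assay. It differs from compound 2 in one place: 4-methylcyclohexyl in place of (pyridin-2-yl)methyl on an amide-type nitrogen. For the measured compounds named here, no pair of measured compounds that differ in a single place is available, so there is no measured step to build on. Given that compound 2 sits at a limit, the expectation is that compound 4 will show no step beyond the usual scatter and will most likely also come back as a limit. On this basis, compound 4 is estimated at 45000 nM, within 18000 nM to 110000 nM, which would mean an expected step of an at least 1.1-fold lower number from compound 2 to compound 4 (0.04 log units; that floor lies within the scatter).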

Compound 4, half-maximal effective concentration: 45000 nM
Estimate against measurement, compound 4: no gap at the digits printed, within the range that was stated.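

In this assay compound 4 gives a measured number, 45000 nM, so this position on the amide-type nitrogen now has its first readable step, where 4-methylcyclohexyl takes the place of (pyridin-2-yl)methyl: an at least 1.1-fold lower number from compound 2 to compound 4 (0.04 log units; that floor lies within the scatter). Going by these compounds, the entry for compound 2 is a limit and not a number: the limit of > 50000 nM in this assay, at which 2 of the 4 values shown sit. The step is therefore only a floor: it shows that a ring of carbon only can stand here and still give a number in this range, but the true size of the change remains unknown and could be larger than the floor.

On these data alone, whether an amine or a carboxylic acid in place of the methyl on the cyclohexyl ring would move the number stays open. So does whether a shorter chain, such as ethyl, would give a value clearly apart from that of compound 4.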